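A Biaryl Amide Series Against the Capsaicin Receptor

The compounds below may be only part of what the source reports. "The series", "measured", "known", "first", "only" and "open" are said of these compounds alone.

Three related compounds have been tested in a functional assay for antagonist activity at transient receptor potential cation channel subfamily V member 1 (Homo sapiens), read by FLIPR; a lower number here means a stronger inhibitor, a higher number a weaker inhibitor. Compound 1 `CC(C)(C)c1ccc(NC(=O)c2ccc(-c3ncccc3NC3CCCC3)cc2)cc1` carries a cyclopentylamino group on its pyridine-containing core, and in this assay compound 1 gives 190 nM. Compound 2 `CCS(=O)(=O)Nc1cccnc1-c1ccc(C(=O)Nc2ccc(C(C)(C)C)cc2)cc1` gives 49 nM. Compound 3 `CC(C)(C)c1ccc(NC(=O)c2ccc(-c3ncccc3N(S(C)(=O)=O)S(C)(=O)=O)cc2)cc1` gives 0.8 nM, the lowest of the three numbers, and its steps to both neighbours lie beyond the scatter: a 240-fold lower number from compound 1 to compound 3 (2.38 log units; beyond the scatter) and a 61-fold lower number from compound 2 to compound 3 (1.79 log units; beyond the scatter).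

Compound 4 `Cc1nnc(-c2cccnc2-c2ccc(C(=O)Nc3ccc(C(C)(C)C)cc3)cc2)o1` has not yet been measured. It differs from compound 3 in one place: 5-methyl-1,3,4-oxadiazol-2-yl in place of bis(methylsulfonyl)amino on an aromatic carbon. The two steps that bear on this change are those leading into compound 3, a 61-fold lower number from compound 2 to compound 3 (1.79 log units; beyond the scatter) and a 240-fold lower number from compound 1 to compound 3 (2.38 log units; beyond the scatter). Both show that the bis(methylsulfonyl)amino group sits at the favourable end of this small set, so removing it is expected to cost potency. Going by the values given here, the step is therefore expected to run upward, a 38-fold higher number from compound 3 to compound 4 (1.57 log units; beyond the scatter), though no measured compound carries a five-membered aromatic ring at this position, so the size is uncertain. Compound 4 is estimated at 30 nM, within a range from 4 nM to 250 nM.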

Compound 4, half-maximal inhibitory concentration: 387 nM
Estimate against measurement, compound 4: 13-fold (1.11 log units) below, outside the stated range (above it).
By their numbers in this assay, from the lowest: compound 3; then compound 2; then compound 1; then compound 4.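

In this assay the change brings a 480-fold higher number from compound 3 to compound 4 (2.68 log units; beyond the scatter) and so shows that the 5-methyl-1,3,4-oxadiazol-2-yl group does not match bis(methylsulfonyl)amino on this aromatic carbon, even though neither group has a hydrogen-bond donor or a net charge. The ring also falls behind the two other groups tested here, with a 7.9-fold higher number from compound 2 to compound 4 (0.90 log units; beyond the scatter) and a 2.0-fold higher number from compound 1 to compound 4 (0.31 log units; beyond the scatter) and thus compound 4 has the highest number of the four, so an uncharged group without a donor does not by itself give strong inhibition at this position. No measurement shown here explains these gaps.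

On these data alone, whether the loss belongs to this ring alone or to five-membered aromatic rings in general remains open. It is also unknown how a plain amine or a single methylsulfonylamino group would compare at this position.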